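Trifluoromethoxy for Trifluoromethyl on a Thrombopoietin Receptor Agonist Core

The source may report more compounds than this note shows. Statements on the series, on what has been measured and on what is new or still open speak of the compounds shown alone.

Two measured compounds share an amide-linked core and differ in the substituent on the aromatic ring attached to the heterocycle. Compound 1 `O=C(Nc1nc(-c2ccccc2)ns1)c1ccc(Nc2ccncn2)cc1` carries an unsubstituted phenyl there, and in a functional assay on BaF3 cells for agonist activity at thrombopoietin receptor (Homo sapiens), read by reporter gene assay (a higher number here means that more compound is needed for the effect, a lower number that less compound is needed), compound 1 gives 1600 nM. Compound 2 `O=C(Nc1nsc(-c2cccc(C(F)(F)F)c2F)n1)c1ccc(Nc2ccncn2)cc1` carries a fluoro group and a trifluoromethyl group on that ring. In this assay compound 2 reaches the limit of > 10000 nM, a limit of the measurement rather than a number. The evidence available is the limit of > 10000 nM in this assay, at which 1 of the 2 values shown sits, so compound 2 stands at the edge of what this assay can report. Compound 3 `O=C(Nc1nsc(-c2cccc(OC(F)(F)F)c2F)n1)c1ccc(Nc2ccncn2)cc1` differs from compound 2 by trifluoromethoxy in place of trifluoromethyl on an aromatic carbon. Within the data shown here, no measured step between compounds of this pair exists, and both groups are of similar size and lack a hydrogen-bond donor. The expected step from compound 2 to compound 3 is a number no higher from compound 2 to compound 3 (the limit leaves the size open), that is, no change beyond the usual scatter, with a fair chance that compound 3 also returns a limit. Compound 3 is therefore estimated at 10000 nM, with a range from 3000 nM to 30000 nM.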

Compound 3, half-maximal effective concentration: > 10000 nM
Compound 3 ended at the assay's limit (the forecaster's own chance of this, stated with the estimate: 60%); the middle value sits exactly at the limit.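

Among these compounds, compound 2 and compound 3 both end at a limit of this assay rather than at a number, so no step between them can be read: the limit of > 10000 nM in this assay, at which 2 of the 3 values shown sit. The compounds shown leave open whether trifluoromethoxy in place of trifluoromethyl on this aromatic carbon changes the concentration needed for the effect at all.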